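The source may hold more compounds than are shown below. What is called first, only, known or untested is meant among the compounds shown, and "the series" means these compounds.

Measured in an ADME assay on MDCK cells (Canis lupus familiaris) for permeability, read by LC-MS, with a stated time of 90 min, tested at 2 uM; a lower number here means that the compound crosses the layer more slowly, a higher number that the compound crosses the layer faster:
- compound 1, `Cc1cc(C)c(CN2CCc3c(Cl)cc([C@@H](CO)[C@@H]4CCOC4)c(Cl)c3C2=O)c(=O)[nH]1`: 3 10^-6 cm/s
- compound 2, `COC(c1cc(Cl)c2c(c1Cl)C(=O)N(Cc1c(C)cc(C)[nH]c1=O)CC2)C1CCN(C2COC2)CC1`: 7 10^-6 cm/s; 7.9 10^-6 cm/s (2 entries)
- compound 3, `COC(c1cc(Cl)c2c(c1Cl)C(=O)N(Cc1c(C)cc(C)[nH]c1=O)CC2)C1CCN(C(C)=O)CC1`: 11.5 10^-6 cm/s; 8.1 10^-6 cm/s (2 entries)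

Compound 1 stands at the low end of the numbers shown in this assay; compound 2 and compound 3 both sit above it, and their repeat entries, the several entries of compound 2 in this assay, 7 10^-6 cm/s; 7.9 10^-6 cm/s (2 entries) and (the several entries of compound 3 in this assay, 11.5 10^-6 cm/s; 8.1 10^-6 cm/s (2 entries)), lie within the usual scatter of one another, so no order between compound 2 and compound 3 is claimed. Compound 1 carries one further pair of entries in this assay that did not return a single number.

Compound 4, `Cc1cc(C)c(CN2CCc3c(Cl)cc([C@@H](C)CO)c(Cl)c3C2=O)c(=O)[nH]1`, has not yet been measured in this assay. It differs from compound 1 in one place: a group of 4 heavy atoms (3 carbon, 1 oxygen; no ring) in place of a group of 8 heavy atoms (6 carbon, 2 oxygen; one five-membered non-aromatic ring with 1 hetero atom), on an aromatic carbon. The 1-(hydroxymethyl)ethyl group keeps the single hydrogen-bond donor of the group it replaces, while the five-membered non-aromatic ring with its extra hydrogen-bond acceptor is gone.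

No measured step of this kind is available among the compounds shown, so the direction rests on the structural change alone. A modest rise in permeability is expected for compound 4, somewhat beyond the scatter, with a 2.0-fold higher number from compound 1 to compound 4 (0.30 log units; within the scatter) as the estimated step from compound 1. Compound 4 is expected to give about 6 10^-6 cm/s in this assay, within a range of 3 10^-6 cm/s to 12 10^-6 cm/s.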

Compound 4, apparent permeability: 15 10^-6 cm/s
Compound 4: middle estimate off by 2.5-fold (0.40 log units), on the low side; measured number above the stated range.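

In this assay, the position on the aromatic carbon ortho to a chloro group now has its first readable step: 1-(hydroxymethyl)ethyl in place of the group of 8 heavy atoms carrying the five-membered non-aromatic ring gives a 5.0-fold higher number from compound 1 to compound 4 (0.70 log units; beyond the scatter). The hydrogen-bond donor count is the same on both sides of this change, so the step comes without any change in donors, while the ring, a hydrogen-bond acceptor, a defined stereocentre and part of the heavy-atom count all go at once. No measurement shown gives a cause for this step.

With only one step at this position, the compounds shown cannot say which of those simultaneous differences goes with the higher number, and an isopropyl group without the hydroxyl, a primary amine in place of the hydroxyl or a cyclopentyl ring without the ring oxygen would each separate part of the change. Going by these compounds alone, compound 2 and compound 3 differ from compound 1 in more than one place, so they give no step for this position, and how far the result carries over to their substituents remains open.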